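The source may hold more compounds than are shown below. What is called first, only, known or untested is meant among the compounds shown, and "the series" means these compounds.

Compound 1 `COc1ccc(Nc2nccc(-c3cccs3)n2)cc1` gives 3900 nM in a functional assay for inhibition, with Homo sapiens as the target; a lower number here means a stronger inhibitor, a higher number a weaker inhibitor.
Compound 2 `COc1ccc(Nc2nccc(-c3ccncc3)n2)cc1` gives 4200 nM in this assay.
Compound 3 `CC1CCN(C(=O)COc2ccc(Nc3nccc(-c4ccncc4)n3)cc2)CC1` gives 300 nM in this assay.

Among these three, compound 2 carries the highest number. Compound 1 sits beside it within the usual scatter a 1.1-fold higher number from compound 1 to compound 2 (0.03 log units; within the scatter), while compound 3 lies far below it a 14-fold lower number from compound 2 to compound 3 (1.15 log units; beyond the scatter).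

Compound 4 `c1cc(-c2ccnc(Nc3ccc(-n4ccnc4)cc3)n2)ccn1` is the next compound to be measured. It differs from compound 2 in one place: 1H-imidazol-1-yl in place of methoxy on an aromatic carbon.

Two measured steps can be weighed against this change. The step from compound 1 to compound 2 alters a different part of the shared core and stays within the scatter, so it says little about the position now being changed. The step from compound 2 to compound 3 does touch the same aromatic carbon: there, building the methoxy out into a much larger group gave a large gain in this assay. That shows the position accepts more than a methoxy, but the group entering in compound 4 is a small aromatic ring rather than that long chain, so only a modest gain in this assay is expected for compound 4, roughly a 2.8-fold lower number from compound 2 to compound 4 (0.45 log units; beyond the scatter). For compound 4 the estimate in this assay is 1500 nM, with a range from 400 nM to 6000 nM.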

Compound 4, half-maximal inhibitory concentration: 7600 nM
The estimate for compound 4 lay 5.1-fold (0.70 log units) below the measured number; measured number above the stated range.
By their numbers in this assay, from the lowest: compound 3; then compounds 1, 2 and 4 (each within the scatter of the next).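

Replacing the methoxy with 1H-imidazol-1-yl, on an aromatic carbon para to a large group, brings five heavy atoms and a five-membered aromatic ring to this position, yet the result in this assay stays within the scatter, with a 1.8-fold higher number from compound 2 to compound 4 (0.26 log units; within the scatter) as the step. A larger group at this carbon is therefore not enough on its own to match the large step seen with the (4-methylpiperidin-1-yl)carbonyl group, a 14-fold lower number from compound 2 to compound 3 (1.15 log units; beyond the scatter), so the earlier gain cannot be read as a simple reward for added size or for adding a ring. No measurement shown here gives a reason for this result.

The compounds shown leave open which part of the group in compound 3 matters: the carbonyl, the piperidine ring or its methyl group, since none of these parts appears alone at this position. A plain amine, a carboxylic acid at the end of the chain on the oxygen, or a longer chain ending in a morpholine ring could each help separate these parts.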